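Anilinoquinazoline thioacetamides: from compound 3 to compound 4

The source may hold more compounds than are shown below. What is called first, only, known or untested is meant among the compounds shown, and "the series" means these compounds.

Compound 1 `O=C(CSc1nc(Nc2ccccc2)c2ccccc2n1)Nc1ccc(Cl)cc1`: 17200 nM
Compound 2 `O=C(CSc1nc(Nc2ccccc2)c2ccccc2n1)Nc1ccc([N+](=O)[O-])cc1`: 16800 nM
Compound 3 `C=CC(=O)Nc1cccc(NC(=O)CSc2nc(Nc3ccccc3Cl)c3ccccc3n2)c1`: 12700 nM

The three measured compounds share one core and were tested in a functional assay on MDA-MB-231 cells (Homo sapiens) for inhibition, read by MTT assay, with a stated time of 72 h; a higher number here means a weaker inhibitor, a lower number a stronger inhibitor. For the measured compounds named here, compound 1 gives 17200 nM, and compound 2 gives 16800 nM; the one measured step between them, a 1.0-fold lower number from compound 1 to compound 2 (0.01 log units; within the scatter), is within the scatter. Compound 3 gives 12700 nM, the lowest of the three numbers, yet its gaps to compound 2 and to compound 1 are both within the scatter, so the three sit together.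

Compound 4 `C=CC(=O)Nc1cccc(NC(=O)CSc2nc(Nc3ccc(C(F)(F)F)cc3)c3ccccc3n2)c1` has not been measured. It differs from compound 3 in one place: 4-(trifluoromethyl)phenyl in place of 2-chlorophenyl on a nitrogen on an aromatic ring. Going by the values given here, no measured step touches this position; the only step known, from compound 1 to compound 2, changes the other aryl amide and was flat. The data therefore give no ground to expect a step beyond the scatter in this assay. The estimate for compound 4 is 13000 nM, with a range of 5000 nM to 35000 nM, meaning an expected step of a 1.0-fold higher number from compound 3 to compound 4 (0.01 log units; within the scatter).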

Compound 4, half-maximal inhibitory concentration: 11500 nM
The estimate for compound 4 lay 1.1-fold (0.05 log units) above the measured number; low and high end bracket the measured number.
By their numbers in this assay, from the lowest: compounds 4, 3, 2 and 1 (each within the scatter of the next).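

For the compounds shown here, this is the first measured step at the aryl group on a nitrogen on an aromatic ring: in this assay, 4-(trifluoromethyl)phenyl in place of 2-chlorophenyl gives a 1.1-fold lower number from compound 3 to compound 4 (0.04 log units; within the scatter). Two aryl groups with different substituents and heavy-atom counts thus read alike at this position, as the change on the other aryl amide did at its own. No measurement shown accounts for this.

From the compounds shown here alone, both groups are aromatic rings of carbon only, so it remains open whether a longer chain carrying an amine or a carboxylic acid on that nitrogen would move the number beyond the scatter. Compound 3 and compound 4 also differ in both the substituent and its place on the ring, so neither change can be read alone.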